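Amide aryl swap on the shared core: cytotoxicity notes

The source may hold more compounds than are shown below. What is called first, only, known or untested is meant among the compounds shown, and "the series" means these compounds.

The series keeps one core and varies only the aryl on the carbonyl carbon of the amide. Compound 1 `O=C(Nc1c(O)cccc1-c1nc2c(C(=O)O)cccc2o1)c1ncccc1F` carries 3-fluoropyridin-2-yl; in an ADME assay on L6 cells (Rattus norvegicus) for cytotoxicity (a lower number here means a stronger inhibitor, a higher number a weaker inhibitor), compound 1 gives 204000 nM. Compound 2 `O=C(Nc1c(O)cccc1-c1nc2c(C(=O)O)cccc2o1)c1ccccc1` carries phenyl. In this assay compound 2 gives only a limit of the assay, > 240000 nM. Among the measured compounds shown here, compound 3 `O=C(Nc1c(O)cccc1-c1nc2c(C(=O)O)cccc2o1)c1cnccn1` carries pyrazin-2-yl, and in this assay compound 3 gives 94400 nM, the lowest of the two numbers so far. The remaining value, that of compound 2, is a limit (the limit of > 240000 nM in this assay, at which 1 of the 3 values shown sits). Both steps into compound 3 ran downward: a 2.2-fold lower number from compound 1 to compound 3 (0.33 log units; beyond the scatter) and an at least 2.5-fold lower number from compound 2 to compound 3 (0.40 log units; beyond the scatter); between 3-fluoropyridin-2-yl and phenyl, an at least 1.1-fold higher number from compound 1 to compound 2 (0.07 log units; that floor lies within the scatter), the floor lies within the scatter.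

Compound 4 `O=C(Nc1c(O)cccc1-c1nc2c(C(=O)O)cccc2o1)c1ncccc1O` differs from compound 3 by 3-hydroxypyridin-2-yl in place of pyrazin-2-yl on a carbonyl carbon. This returns to a ring with one hetero atom, as in compound 1. In this assay a modest upward step is therefore expected, a 1.7-fold higher number from compound 3 to compound 4 (0.23 log units; within the scatter), roughly undoing a 2.2-fold lower number from compound 1 to compound 3 (0.33 log units; beyond the scatter). For compound 4 the expected value is 160000 nM, with a range of 70000 nM to 320000 nM.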

Compound 4, half-maximal inhibitory concentration: 14200 nM
Compound 4: middle estimate off by 11-fold (1.05 log units), on the high side; the measured number lies below the stated range.
By their numbers in this assay, from the lowest: compound 4; then compound 3; then compound 1. At a limit, above all of these: compound 2.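

In this assay hydroxy in place of fluoro on an aromatic carbon gives a 14-fold lower number from compound 1 to compound 4 (1.16 log units; beyond the scatter) and leaves the rest of compound 1 unchanged, so at this position the group on the pyridin-2-yl ring can move the number strongly. Pyrazin-2-yl no longer marks the low end of the series: 3-hydroxypyridin-2-yl in its place on the carbonyl carbon gives a 6.6-fold lower number from compound 3 to compound 4 (0.82 log units; beyond the scatter) and puts compound 4 lowest of the numbers shown. Against phenyl the change gives an at least 16-fold lower number from compound 2 to compound 4 (1.22 log units; beyond the scatter) and this is only a floor, as the reading for compound 2 is a limit of the assay.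

On these data alone, whether a methoxy group or an amine in place of the hydroxy would keep this step remains open. What lies behind the step also remains open, as nothing measured here bears on its cause.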